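Cytotoxicity notes: from compound 2 to compound 4

A few compounds are considered here, and "the series" means these few. Any claim that something is new, unique, unknown or untested is made for them only; others in the source may bear on it.

The series was profiled in an ADME assay on NCM460 cells (Homo sapiens) for cytotoxicity, read by MTT assay, with a stated time of 72 h; a higher number here means a weaker inhibitor, a lower number a stronger inhibitor. Compound 1 `CCCCCN1C(=O)C/C(=C\c2cccc(C(=O)NCCCC)c2)C1=O` returns a limit of the assay and not a number, > 100000 nM. Compound 2 `COc1ccc(NC(=O)c2cccc(/C=C3\CC(=O)N(c4ccccc4)C3=O)c2)c(C)c1` likewise returns only a limit, > 100000 nM. Compound 3 `COc1cc(NC(=O)c2cccc(/C=C3\CC(=O)N(c4ccccc4)C3=O)c2)cc(OC)c1OC` also sits at a limit, > 100000 nM. Compound 2 therefore stands where every value shown stands, at the limit of > 100000 nM in this assay, at which 3 of the 3 values shown sit, and no ordering among the three compounds can be read. Compound 4 `O=C(Nc1cccc(F)c1)c1cccc(/C=C2\CC(=O)N(c3ccccc3)C2=O)c1` is not yet measured. Its change from compound 2 is 3-fluorophenyl in place of 4-methoxy-2-methylphenyl on an amide-type nitrogen. Going by the values given here, no step between measured compounds exists to guide the size of this change. With all three values sitting at the limit, the expected step that the limit leaves unreadable from compound 2 to compound 4 is none beyond the scatter, and this assay is expected to report only a limit again. Compound 4 is expected at 200000 nM, between 100000 nM and 500000 nM.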

Compound 4, half-maximal inhibitory concentration: > 100000 nM
Compound 4: no number, only a limit; the forecaster's own chance of this, stated with the estimate: 90%; the middle value lies beyond the limit too.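

Going by these compounds alone, compound 2 and compound 4 both return only a limit of the assay, and no step between them can be read. The compounds shown leave open whether any amide substituent gives a measurable value in this assay.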